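Trading an isopropyl group for a single chlorine on the benzyl ring

The source may report more compounds than this note shows. Statements on the series, on what has been measured and on what is new or still open speak of the compounds shown alone.

Of the compounds shown here, three sharing one core have been measured in a functional assay on HEK293 cells for agonist activity at G-protein coupled receptor 39 (Homo sapiens), read by scintillation proximity assay and inositol phosphate accumulation, with a stated time of 75 min; on this read-out lower numbers stand for an effect already at smaller amounts and higher numbers for an effect only at larger amounts of compound. Compound 1 `Cc1nn(-c2ncnc3nc[nH]c23)c2c1C(OCc1ccc(Cl)cc1Cl)CC(=O)N2` gives 243 nM. Compound 2 `Cc1nn(-c2ncnc3nc[nH]c23)c2c1C(OCc1ccc(C(C)C)cc1)CC(=O)N2` gives 1690 nM, and compound 3 `Cc1nn(-c2ncnc3nc[nH]c23)c2c1C(C(=O)N(C)c1ccccc1)CC(=O)N2` gives 5220 nM. Compound 2 thus stands second highest of the three numbers, closer to compound 3 than to compound 1.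

Compound 4 `Cc1nn(-c2ncnc3nc[nH]c23)c2c1C(OCc1ccccc1Cl)CC(=O)N2` is not yet measured. Its change from compound 2 is 2-chlorophenyl in place of 4-isopropylphenyl on a saturated chain carbon bound to an oxygen on a saturated carbon.

The step that bears most directly on this is a 7.0-fold higher number from compound 1 to compound 2 (0.84 log units; beyond the scatter), where the 2,4-dichlorophenyl group was the one that gave the lower number. Compound 4 carries a single chlorine on the same ring, so it moves part of the way back toward compound 1. The step of a 21-fold higher number from compound 1 to compound 3 (1.33 log units; beyond the scatter) concerns a different part of the molecule and matters less here. A lower number than compound 2 is therefore expected, and the step of a 3.1-fold lower number from compound 2 to compound 4 (0.49 log units; beyond the scatter) is the estimated size of that gain. Compound 4 is expected to give about 550 nM, within a range from 200 nM to 1500 nM.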

Compound 4, half-maximal effective concentration: 47 nM
Beside the measured number, compound 4's estimate is 12-fold (1.07 log units) above it; the whole stated range lies above it.
By their numbers in this assay, from the lowest: compound 4; then compound 1; then compound 2; then compound 3.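

In this assay, going by these compounds alone, a second chlorine on this ring is no advantage: 2-chlorophenyl in place of 2,4-dichlorophenyl gives a 5.2-fold lower number from compound 1 to compound 4 (0.71 log units; beyond the scatter) and so lowers the number, while the earlier compounds alone could not separate the effects of the two chlorines. The change from 4-isopropylphenyl to 2-chlorophenyl gives a 36-fold lower number from compound 2 to compound 4 (1.56 log units; beyond the scatter) and shows how strongly this position responds to what the ring carries, and the change to (2-chlorobenzyl)oxy from methyl(phenyl)carbamoyl on the saturated ring carbon gives a 110-fold lower number from compound 3 to compound 4 (2.05 log units; beyond the scatter). Nothing available explains why the ring with one chlorine gives the lowest number of the four.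

Going by these compounds, whether the remaining chlorine is needed at all stays open, as does whether a fluorine, methyl or methoxy group could stand in for it. A longer chain between the oxygen and the ring is also an open question.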